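A methoxy group enters the aryl ring of compound 3

The compounds below may be only part of what the source reports. "The series", "measured", "known", "first", "only" and "open" are said of these compounds alone.

In a functional assay on KBVIN cells (Homo sapiens) for antiproliferative activity, read by sulforhodamine B assay, with a stated time of 3 days (on this read-out higher numbers stand for an effect only at larger amounts of compound and lower numbers for an effect already at smaller amounts), compound 1 `CCC1=C(O)c2c(oc(-c3ccc(C(C)C)cc3)cc2=O)C(CC)(CC)C1=O` gives 1.08 uM while compound 2 `CCC1=C(O)c2c(oc(-c3ccccc3C)cc2=O)C(CC)(CC)C1=O` gives 2.41 uM and compound 3 `CCC1=C(O)c2c(oc(-c3ccc(C)c(Cl)c3)cc2=O)C(CC)(CC)C1=O` gives 2.15 uM on the same read-out. Compound 3 lies within the scatter of both others, as shown by the step of a 2.0-fold higher number from compound 1 to compound 3 (0.30 log units; within the scatter) and the step of a 1.1-fold lower number from compound 2 to compound 3 (0.05 log units; within the scatter) on this scale.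

Among the compounds with values here, compound 4 `CCC1=C(O)c2c(oc(-c3ccc(OC)c(C)c3)cc2=O)C(CC)(CC)C1=O` keeps the shared core and carries 4-methoxy-3-methylphenyl in place of 3-chloro-4-methylphenyl on an aromatic carbon next to the ring oxygen 4-methoxy-3-methylphenyl in place of 3-chloro-4-methylphenyl on an aromatic carbon as its only change.

All three measured steps exchange the group at this same place. Within the data shown here, only the step of a 2.2-fold higher number from compound 1 to compound 2 (0.35 log units; beyond the scatter) passes the scatter, and it is modest. Among the measured compounds shown here, no measured compound carries a methoxy group, so the data give no direct precedent for it. The expectation therefore rests on this narrow spread, and no shift beyond the scatter is expected in this assay for the estimated step of a 1.1-fold lower number from compound 3 to compound 4 (0.03 log units; within the scatter) here. For compound 4 the estimated value is 2 uM with an expected range from 1 uM to 4 uM.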

Compound 4, concentration for half-maximal effect: 0.1 uM
Beside the measured number, compound 4's estimate is 20-fold (1.30 log units) above it; measured number outside the range, below it.
By their numbers in this assay, from the lowest: compound 4; then compounds 1, 3 and 2 (each within the scatter of the next, the first and the last beyond it).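

The aromatic carbon next to the ring oxygen proves far more sensitive in this assay than the earlier exchanges suggested: 4-methoxy-3-methylphenyl gives a 22-fold lower number from compound 3 to compound 4 (1.33 log units; beyond the scatter), and the same holds against the other two aryl groups, with a 24-fold lower number from compound 2 to compound 4 (1.38 log units; beyond the scatter) and an 11-fold lower number from compound 1 to compound 4 (1.03 log units; beyond the scatter). Compound 4 is the only compound shown with a methoxy group, and with all three of its steps beyond the scatter it stands as the most potent of the four on this read-out. The exchange replaces the whole aryl group, so the methoxy group cannot be separated from the loss of the chlorine or the changed place of the methyl, and nothing given here accounts for the size of the step.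

The compounds shown leave open whether 4-methoxyphenyl without the methyl would keep this value. They also leave open whether an ethoxy or a hydroxyl group in place of the methoxy would do the same.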